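Replacing the Hydroxyethyl Amide Substituent with a Carboxycyclopropyl Group

The source may hold more compounds than are shown below. What is called first, only, known or untested is meant among the compounds shown, and "the series" means these compounds.

Measured compounds:
compound 1 `CCn1c(C(=O)NCCO)ccc1C(CC)(CC)c1ccc(OCS(=O)(=O)c2ccccc2)c(C)c1` — 19900 nM
compound 2 `CCn1c(C(=O)N[C@H](C)CO)ccc1C(CC)(CC)c1ccc(OCS(=O)(=O)c2ccccc2)c(C)c1` — 10000 nM
compound 3 `CCn1c(C(=O)N[C@H](CO)CCCO)ccc1C(CC)(CC)c1ccc(OCS(=O)(=O)c2ccccc2)c(C)c1` — > 50000 nM

Of the compounds shown here, three sharing one core have been tested in a functional assay on BXPC-3 cells (Homo sapiens) for antiproliferative activity, read by MTT assay, with a stated time of 24 h; a lower number here means a stronger inhibitor, a higher number a weaker inhibitor. Compound 1 gives 19900 nM, the highest of the two numbers reported as values. Compound 2 gives 10000 nM, and the step of a 2.0-fold lower number from compound 1 to compound 2 (0.30 log units; within the scatter) lies within the scatter. For compound 3 the assay reports only a limit, > 50000 nM. That reading for compound 3 is the limit of > 50000 nM in this assay, at which 1 of the 3 values shown sits. Against that limit the steps of an at least 2.5-fold higher number from compound 1 to compound 3 (0.40 log units; beyond the scatter) and an at least 5.0-fold higher number from compound 2 to compound 3 (0.69 log units; beyond the scatter) are both beyond the scatter.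

Compound 4 `CCn1c(C(=O)NC2(C(=O)O)CC2)ccc1C(CC)(CC)c1ccc(OCS(=O)(=O)c2ccccc2)c(C)c1` has not yet been measured. It differs from compound 1 in one place: 1-carboxycyclopropyl in place of 2-hydroxyethyl on an amide-type nitrogen. The measured steps that bear on this are those that enlarge the group on the amide nitrogen: the small addition in a 2.0-fold lower number from compound 1 to compound 2 (0.30 log units; within the scatter) changed little, whereas the larger addition in an at least 2.5-fold higher number from compound 1 to compound 3 (0.40 log units; beyond the scatter) pushed the value out of range. The group entering in compound 4 is larger than the one it replaces, so a modestly higher number is expected, with a real chance that the assay again reports only a limit. Compound 4 is therefore expected to give about 35000 nM, in the range 12000 nM to 100000 nM. The estimated step is a 1.8-fold higher number from compound 1 to compound 4 (0.25 log units; within the scatter).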

Compound 4, half-maximal inhibitory concentration: > 50000 nM
Compound 4: no number, only a limit; the forecaster's own chance of this, stated with the estimate: 40%; at least 1.4-fold (0.15 log units) between middle value and limit.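

In this assay compound 4 gives only a limit, > 50000 nM. Exchanging 2-hydroxyethyl for 1-carboxycyclopropyl on the amide-type nitrogen gives an at least 2.5-fold higher number from compound 1 to compound 4 (0.40 log units; beyond the scatter), and the comparison with the 1-(hydroxymethyl)ethyl group gives an at least 5.0-fold higher number from compound 2 to compound 4 (0.69 log units; beyond the scatter), so the earlier picture of one long hydroxyalkyl chain losing activity at this position now extends to a group of a different kind, with a three-membered ring and a carboxyl group, though compound 2 shows that not every enlargement here has this result. The step between compound 3 and compound 4 cannot be read, so the two compounds cannot be ranked, and this position now holds two different groups at the same assay limit: the limit of > 50000 nM in this assay, at which 2 of the 4 values shown sit.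

The compounds shown leave open whether the ring or the carboxyl part of the new group goes with this result; a plain cyclopropyl group or an open-chain carboxymethyl group on the amide-type nitrogen would separate the two. From the compounds shown here alone, how much activity, if any, compound 3 and compound 4 retain also stays open.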